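This account rests on a few compounds, and the source may have more. Where it says the series, first, only, none or still open, it means among the compounds named here.

Values so far in a physicochemical assay for lipophilicity, at pH 7.4 (on this read-out lower numbers stand for lower lipophilicity and higher numbers for higher lipophilicity), are these:
- compound 1 `CNC(=O)c1cc(C(=O)NC2CC2)cn(Cc2ccc(C)cc2)c1=O` gives 3.5 
- compound 2 `CNC(=O)c1cc(C(=O)NC2CC2)cn([C@H](C)c2ccccc2)c1=O` gives 3.4 

Among the compounds with values here, with only these two numbers, compound 1 cannot be told apart from compound 2, since the one measured step (a number 0.10 log units lower from compound 1 to compound 2 (within the scatter)) stays within the scatter. Compound 3 `CNC(=O)c1cc(C(=O)NC2CC2)cn(Cc2cccc3[nH]ccc23)c1=O` has not yet been measured. It keeps the core of compound 1 and changes one group on a saturated chain carbon bound to an aromatic nitrogen, with 1H-indol-4-yl in place of 4-methylphenyl (1H-indol-4-yl in place of 4-methylphenyl on a saturated chain carbon bound to an aromatic nitrogen). Within the data shown here, the one measured step changes a group on the same aromatic nitrogen and is small, but it brings in no 1H-indol-4-yl, so it is only a weak guide. Among the measured compounds shown here, no measured compound carries the hydrogen-bond donor that enters here, so the direction is a loose judgement. The expected change in this assay is small and downward (a number 0.30 log units lower from compound 1 to compound 3 (within the scatter)) and could turn out to be no real change at all. Compound 3 is estimated at 3.2 with an expected range from 2.8 to 3.6 for the coming measurement.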

Compound 3, distribution coefficient: 2.9
Beside the measured number, compound 3's estimate is 0.30 log units above it; measured number inside the range.
By their numbers in this assay, from the lowest: compound 3; then compounds 2 and 1 (each within the scatter of the next).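

In this assay, the group on the saturated chain carbon bound to an aromatic nitrogen now shows a readable effect: putting 1H-indol-4-yl in place of 4-methylphenyl gives a number 0.60 log units lower from compound 1 to compound 3 (beyond the scatter). Within the data shown here, the earlier step at this nitrogen, a number 0.10 log units lower from compound 1 to compound 2 (within the scatter), could not separate its two compounds, so compound 3 is the first here that stands apart from compound 1. The entering group has more heavy atoms than the one it replaces, 9 against 7, and adds a five-membered aromatic ring with 1 hetero atom and 1 hydrogen-bond donor, yet no measurement at hand says which of these differences accounts for the lower number.

A single change brings in all of these features together, so the compounds shown cannot divide the step among them. An indole carrying a methyl group on its ring nitrogen would test the part played by the hydrogen-bond donor, while an amine or a carboxylic acid on the phenyl ring would show how far the number moves with other groups at this place.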